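Moving the chlorine on the anilide ring of compound 2

A few compounds are considered here, and "the series" means these few. Any claim that something is new, unique, unknown or untested is made for them only; others in the source may bear on it.

Measured compounds:
compound 1 `CCCCCNC(=O)Oc1ccc(Cl)cc1C(=O)Nc1cccc(Cl)c1`, 5.11
compound 2 `CCCCCCCCNC(=O)Oc1ccc(Cl)cc1C(=O)Nc1cccc(Cl)c1`, 6.36
compound 3 `CCCCCCCCCNC(=O)Oc1ccc(Cl)cc1C(=O)Nc1cccc(Cl)c1`, 6.78

In a physicochemical assay for lipophilicity (a lower number here means a more polar compound, a higher number a more lipophilic compound), compound 2 stands second highest of the three: compound 3 lies a number 0.42 log units higher from compound 2 to compound 3 (beyond the scatter) and compound 1 lies a number 1.25 log units higher from compound 1 to compound 2 (beyond the scatter) the other way. Compound 4 `CCCCCCCCNC(=O)Oc1ccc(Cl)cc1C(=O)Nc1ccc(Cl)cc1` differs from compound 2 only in 4-chlorophenyl in place of 3-chlorophenyl on an amide-type nitrogen. Among the compounds with values here, none of the measured steps bears on this change: they all concern the chain on the carbamate nitrogen, as with a number 1.67 log units higher from compound 1 to compound 3 (beyond the scatter), and none moves the chlorine on the anilide ring. The atoms stay the same, so no step beyond the scatter is expected in this assay; the step from compound 2 to compound 4 is estimated as no change at the digits printed from compound 2 to compound 4 (within the scatter). Compound 4 is therefore expected near 6.36, between 6.05 and 6.7.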

Compound 4, partition coefficient: 6.36
Estimate against measurement, compound 4: no gap at the digits printed; low and high end bracket the measured number.
By their numbers in this assay, from the lowest: compound 1; then compounds 2 and 4 (each within the scatter of the next); then compound 3.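

In this assay, 4-chlorophenyl in place of 3-chlorophenyl on an amide-type nitrogen gives no change at the digits printed from compound 2 to compound 4 (within the scatter) and so leaves the reading in place. Within the data shown here, the earlier compounds differed only in the chain on the carbamate nitrogen, so this is the first reading of a change on the anilide ring. Nothing shown gives a reason for this result.

From the compounds shown here alone, whether the same holds with the chlorine replaced by a trifluoromethyl or a carboxylic acid stays open. So does whether moving the chlorine has the same outcome with the chains of compound 1 or compound 3.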